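The source may report more compounds than this note shows. Statements on the series, on what has been measured and on what is new or still open speak of the compounds shown alone.

Compound 2 `O=C(O)/C=C/c1ccncc1-c1ccc2ccccc2c1` carries hydroxy on its carbonyl carbon. In an assay on a protein complex for inhibition of CDK8/Cyclin C (Homo sapiens), with a stated time of 1 h, tested at 10 uM (on this read-out higher numbers stand for more inhibition at the one concentration tested (going by the name of the read-out) and lower numbers for less inhibition), compound 2 gives 102%, the highest of the three numbers in hand. Compound 3 `O=C(CCc1ccncc1-c1ccc2ccccc2c1)N1CCOCC1` lies nearest: in this assay compound 3 gives 100%, within the scatter of compound 2. Compound 1 `O=C(O)[C@@H]1CCCN1C(=O)/C=C/c1ccncc1-c1ccc2ccccc2c1`, which carries 2-carboxypyrrolidin-1-yl on the carbonyl carbon, lies furthest: in this assay compound 1 gives 67%. For the measured compounds named here, the single measured step, a number 35 percentage points higher from compound 1 to compound 2 (beyond the scatter), shows that the group on this carbonyl carbon can shift the number a long way.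

Compound 4 `O=C(/C=C/c1ccncc1-c1ccc2ccccc2c1)NC1CC1` differs from compound 2 at that same carbonyl carbon: cyclopropylamino in place of hydroxy on a carbonyl carbon. Going by the values given here, no measured step follows exactly this change. Compound 3, which also has no hydroxy on its carbonyl carbon, gives a number within the scatter of compound 2, whereas compound 1 with its larger group fell well short. A small drop, or none beyond the scatter, is therefore expected in this assay, with more room on the downside. Compound 4 is expected to give 90%, with a range from 65% to 105%. The expected step is a number 12 percentage points lower from compound 2 to compound 4 (beyond the scatter).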

Compound 4, a percentage reported as inhibition, at one concentration (the size of the read-out at that concentration, not a potency): 102%
For compound 4 the middle estimate is 12 percentage points below the measured one; measured number inside the range.
By their numbers in this assay, from the lowest: compound 1; then compounds 3, 2 and 4 (each within the scatter of the next).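

In this assay, putting cyclopropylamino in place of hydroxy on this carbonyl carbon makes no difference beyond the scatter, no change at the digits printed from compound 2 to compound 4 (within the scatter), so the free acid is not needed for a high number at this position. The second step, a number 35 percentage points higher from compound 1 to compound 4 (beyond the scatter), adds that the low number of compound 1 does not extend to every amide at this carbonyl carbon: one with a three-membered ring reads high, while the one with 2-carboxypyrrolidin-1-yl falls short. No supporting measurement explains why these two groups part ways.

Going by these compounds, it remains open where the number begins to fall between these two groups, for instance with pyrrolidin-1-yl, which has no carboxy, or with a longer chain such as butylamino. On these data alone, because this read-out comes from one concentration, any difference in potency between compound 2 and compound 4 also remains open.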